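The compounds below may be only part of what the source reports. "The series", "measured", "known", "first", "only" and "open" are said of these compounds alone.

Working notes on the series.

Three compounds of this set have been run in an assay on isolated protein for binding affinity to metabotropic glutamate receptor 5 (Homo sapiens) (on this read-out lower numbers stand for stronger inhibition and higher numbers for weaker inhibition), so far. Compound 1, `O=C(Nc1cccc(Cl)c1)c1cccc2oc(=O)[nH]c12`, gives 68 nM and holds the lowest of the two numbers measured. Compound 3, `O=C1COc2cccc(C(=O)Nc3cccc(Cl)c3)c2N1`, an isomeric arrangement of the fused ring portion, gives 2900 nM, a gap from compound 1 that lies well beyond the usual scatter. For the measured compounds named here, compound 2, `O=C(Nc1cccc(Cl)c1)c1cccc2[nH]c(=O)oc12`, is reported only as > 10000 nM, which is a limit of this assay and not a number; it is the one value sitting at the limit of > 10000 nM in this assay, at which 1 of the 3 values shown sits.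

Compound 4, `Cc1cccc(NC(=O)c2cccc3oc(=O)[nH]c23)c1`, keeps the fused core of compound 1 and changes only the anilide: methyl in place of chloro on an aromatic carbon. Going by the values given here, no measured pair in the set isolates this change, so the expectation rests on compound 1 alone. The step from compound 1 to compound 4 in this assay is expected to be small, a 2.2-fold higher number from compound 1 to compound 4 (0.34 log units; beyond the scatter), most likely a slight weakening or none beyond the scatter. Compound 4 is accordingly estimated at 150 nM, with a plausible range from 50 nM to 500 nM.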

Compound 4, inhibition constant: 109 nM
Compound 4: middle estimate off by 1.4-fold (0.14 log units), on the high side; the range from low to high includes it.
By their numbers in this assay, from the lowest: compounds 1 and 4 (each within the scatter of the next); then compound 3. At a limit, above all of these: compound 2.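

For the compounds shown here, compound 1 to compound 4 is the first step that isolates a single change, since the earlier compounds differ from one another only in the fused ring portion. In this assay, methyl in place of chloro on an aromatic carbon, meta to a large group, gives a 1.6-fold higher number from compound 1 to compound 4 (0.20 log units; within the scatter), so on the core of compound 1 the chlorine is not needed at this place to keep the number within the scatter. Nothing at hand gives a reason for this step.

As far as these compounds go, it remains open whether this place accepts groups other than chloro and methyl, such as an amine, a carboxylic acid or a longer chain. From the compounds shown here alone, it also remains open whether methyl and chloro would compare in the same way on the core of compound 3.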